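Changing the piperazine substituent on compound 1 for metabolic stability

A few compounds are considered here, and "the series" means these few. Any claim that something is new, unique, unknown or untested is made for them only; others in the source may bear on it.

Measured compounds:
- compound 1, `CN(C[C@H]1Cc2c(cccc2N2CCN(C3CC3)CC2)CN1)[C@H]1CCCc2cccnc21`: 7%
- compound 2, `c1cnc2c(c1)CCC[C@@H]2N(CC1CCCCC1)C[C@H]1Cc2c(cccc2N2CCNCC2)CN1`: 85.6%
- compound 3, `CN1CCN(c2cccc3c2C[C@H](CN(C)[C@H]2CCCc4cccnc42)N(C)C3)CC1`: 41.7%

In an ADME assay on microsomes from liver (Mus musculus) for metabolic stability, read by LC-MS, with a stated time of 10 min (a lower number here means that less of the compound is left, a higher number that more of the compound is left), compound 1 gives 7%, the lowest of the three numbers. Its nearest neighbour is compound 3, which gives 41.7%, a gap beyond the scatter; the furthest is compound 2, which gives 85.6%, also beyond the scatter. Compound 2 and compound 3 each differ from compound 1 in more than one place, so no single-change step can be read from them.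

The next compound, compound 4, is `CN(C[C@H]1Cc2c(cccc2N2CCNC(C)(C)C2)CN1)[C@H]1CCCc2cccnc21`. It differs from compound 1 in one place: 3,3-dimethylpiperazin-1-yl in place of 4-cyclopropylpiperazin-1-yl on an aromatic carbon. The change sits on an aromatic carbon of a six-membered aromatic ring of carbon only, part of a fused system of two rings, ortho to a fused ring and meta to a fused ring. The group that leaves carries no hydrogen-bond donor; the group that enters carries one.

For the measured compounds named here, no measured pair shows this exact change, so the direction has to be estimated from the three numbers alone. Since compound 1 gives 7%, little room remains downward, and the step is expected to be upward, a number 15 percentage points higher from compound 1 to compound 4 (beyond the scatter), probably beyond the scatter but well short of compound 2. Compound 4 is therefore expected to give about 22% in this assay, within a range from 5% to 50%.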

Compound 4, percent of the compound remaining: 44%
Beside the measured number, compound 4's estimate is 22 percentage points below it; low and high end bracket the measured number.
By their numbers in this assay, from the lowest: compound 1; then compounds 3 and 4 (each within the scatter of the next); then compound 2.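

In this assay, for the compounds shown here, putting 3,3-dimethylpiperazin-1-yl in place of 4-cyclopropylpiperazin-1-yl on an aromatic carbon gives a number 37 percentage points higher from compound 1 to compound 4 (beyond the scatter), the first step in this set that can be read from a single change. It shows that, with the rest of compound 1 left as it is, the group at this place on the shared core can by itself move the number by a large step, something compound 2 and compound 3 could not show, as each differs from compound 1 in more than one place. No measurement at hand says why the step has this size.

The compounds shown leave open which part of the change carries the step, since the cyclopropyl leaves, the two methyl groups enter and a hydrogen-bond donor enters all at once. Also open, on these data alone, is how a morpholin-4-yl or a 4-acetylpiperazin-1-yl group would read at this place on the core of compound 1, and whether a step of this size would recur with other groups on the rest of the molecule.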